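The source may hold more compounds than are shown below. What is called first, only, known or untested is meant among the compounds shown, and "the series" means these compounds.

In a physicochemical assay for lipophilicity, read by LC-MS, in phosphate buffer, measured as octanol-water partition, with a stated time of 30 min, at pH 7.4, tested at 200 mM (a lower number here means a more polar compound, a higher number a more lipophilic compound), two compounds have been measured so far:

compound 1 `Cc1ccc(Oc2ccc3nc(COc4cccc(C(=O)O)c4)n(C)c3n2)cc1C`: 2.2
compound 2 `Cc1cccnc1Oc1ccc2nc(COc3cccc(C(=O)O)c3)n(C)c2c1`: 0.9

Compound 2 is the lower of the two, sitting well under compound 1, a gap beyond the usual scatter. The next compound, compound 3 `Cc1cc(Cl)cnc1Oc1ccc2nc(COc3cccc(C(=O)O)c3)n(C)c2c1`, differs from compound 2 by one change: chloro in place of hydrogen on an aromatic carbon. Among the measured compounds shown here, no measured pair shows this change, so the expectation rests on compound 2 alone. In this assay the step from compound 2 to compound 3 is expected to be upward and beyond the scatter, estimated at a number 0.60 log units higher from compound 2 to compound 3 (beyond the scatter). Starting from compound 2 and its 0.9, compound 3 is expected to give 1.5, within a range from 1.1 to 1.9.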

Compound 3, distribution coefficient: 1.8
The estimate for compound 3 lay 0.30 log units below the measured number, within the range that was stated.
By their numbers in this assay, from the lowest: compound 2; then compound 3; then compound 1.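

Among the compounds shown here, compound 2 and compound 3 form the first measured pair that differs in one place, and in this assay the chloro change on the 3-methylpyridin-2-yl ring reads as a number 0.90 log units higher from compound 2 to compound 3 (beyond the scatter). A single chlorine atom on this carbon, two atoms from the ring nitrogen and para to a large group, is thus enough to move the number beyond the scatter. Nothing on hand accounts for the size of this step. From the compounds shown here alone, whether fluoro, methoxy or an amine on this carbon would give a like step stays open. So does the size of the step for chloro on another carbon of this ring.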